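Lengthening the amide chain of a benzenesulfonamide

The source may hold more compounds than are shown below. What is called first, only, known or untested is meant among the compounds shown, and "the series" means these compounds.

Measured compounds:
compound 1, `CCOC(=O)c1ccc(S(N)(=O)=O)cc1`, 1.17
compound 2, `CNC(=O)c1ccc(S(N)(=O)=O)cc1`, -0.31

In a physicochemical assay for lipophilicity (a lower number here means a more polar compound, a higher number a more lipophilic compound), compound 1 gives 1.17, and compound 2 gives -0.31, the lowest of the two numbers, with compound 1 as its nearest neighbour. Going by the values given here, the only measured step, a number 1.48 log units lower from compound 1 to compound 2 (beyond the scatter), is large and lies beyond the scatter.

Compound 3, `CCCCCNC(=O)c1ccc(S(N)(=O)=O)cc1`, has not yet been measured in this assay. It differs from compound 2 by butyl in place of hydrogen on a saturated chain carbon bound to an amide-type nitrogen. Among the compounds with values here, no measured step bears directly on this change: the step from compound 1 to compound 2 replaces ethoxy with methylamino on a carbonyl carbon, and does not lengthen a saturated chain. The expectation for compound 3 therefore rests on the size of the entering butyl group alone, and a rise beyond the scatter is expected.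

Compound 3 is estimated at 1.7, with a range from 1.2 to 2.2. This estimate means an expected step of a number 2.01 log units higher from compound 2 to compound 3 (beyond the scatter).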

Compound 3, partition coefficient: 1.54
Estimate against measurement, compound 3: 0.16 log units above; the range from low to high includes it.
By their numbers in this assay, from the lowest: compound 2; then compound 1; then compound 3.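

In this assay the amide chain proves a strongly responsive place: butyl in place of hydrogen on a saturated chain carbon bound to an amide-type nitrogen gives a number 1.85 log units higher from compound 2 to compound 3 (beyond the scatter) and counts as a large step. The amide series is also not confined to the low end of the scale set by compound 2, since the change from the ester to the pentyl amide gives a number 0.37 log units higher from compound 1 to compound 3 (beyond the scatter) and so carries the number past that of the ester, a modest step that still lies beyond the scatter. No supporting data accompany these steps, so what lies behind their size remains unexplained.

With only methylamino and pentylamino on this carbonyl, the compounds shown leave open how the number moves along the chain, whether it climbs evenly through propyl or levels off at a longer chain such as octyl. They also leave open what a chain ending in an amine or a hydroxyl group, or a cyclohexyl group in place of the butyl, would do at this place.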